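The compounds below may be only part of what the source reports. "The series", "measured", "known", "first", "only" and "open" are said of these compounds alone.

For the measured compounds named here, in a physicochemical assay for lipophilicity (on this read-out higher numbers stand for higher lipophilicity and lower numbers for lower lipophilicity), three compounds that share one core have numbers so far. Compound 1 `COc1cc(-c2noc([C@H](C)NC(=O)c3cc(C(F)(F)F)nn3C)n2)ccn1`, which carries methoxy, gives 3.4. Compound 2 `C[C@H](NC(=O)c1cc(C(F)(F)F)nn1C)c1nc(-c2ccnc(N3CCCC3)c2)no1`, with pyrrolidin-1-yl in that place, gives 4.2. Compound 3 `C[C@H](NC(=O)c1cc(C(F)(F)F)nn1C)c1nc(-c2ccnc(C3CC3)c2)no1`, with cyclopropyl there, gives 4.1. Compound 3 therefore sits together with compound 2 at the top of these three, clear of compound 1.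

Compound 4 `COCc1cc(-c2noc([C@H](C)NC(=O)c3cc(C(F)(F)F)nn3C)n2)ccn1` differs from compound 3 in one place, with methoxymethyl in place of cyclopropyl on an aromatic carbon.

Going by the values given here, no measured step makes this exact swap. The nearest guide is a number 0.70 log units higher from compound 1 to compound 3 (beyond the scatter), since methoxy, like methoxymethyl, contains oxygen. The change a number 0.80 log units higher from compound 1 to compound 2 (beyond the scatter) is of similar size, while a number 0.10 log units lower from compound 2 to compound 3 (within the scatter) shows no separation. Reading the first of these backwards, a modest fall in this assay is expected, and the estimated step is a number 0.80 log units lower from compound 3 to compound 4 (beyond the scatter). Compound 4 is expected at 3.3, with an estimated range of 2.9 to 3.7.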

Compound 4, distribution coefficient: 3
Beside the measured number, compound 4's estimate is 0.30 log units above it; the range from low to high includes it.
By their numbers in this assay, from the lowest: compound 4; then compound 1; then compounds 3 and 2 (each within the scatter of the next).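

At this position, next to the ring nitrogen, replacing methoxy with methoxymethyl gives a number 0.40 log units lower from compound 1 to compound 4 (beyond the scatter) in this assay, so compound 4 is the first of these compounds to fall below the methoxy compound. Cyclopropyl and methoxymethyl each have 3 heavy atoms, yet exchanging them gives a number 1.10 log units lower from compound 3 to compound 4 (beyond the scatter) and this shows that group size alone does not set the number here. Replacing pyrrolidin-1-yl gives a similar change, a number 1.20 log units lower from compound 2 to compound 4 (beyond the scatter) and no measurement here explains either large step.

The exchange from cyclopropyl both opens the ring and brings in oxygen, so the share of each change remains unresolved. A carbon-only chain such as propyl and an oxygen-containing ring such as oxetanyl at this position would help to separate the two.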